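Ethyl in Place of tert-Butyl: Compound 2 to Compound 3

A few compounds are considered here, and "the series" means these few. Any claim that something is new, unique, unknown or untested is made for them only; others in the source may bear on it.

Of the compounds shown here, two that share a core have been measured in an assay on isolated protein for displacement of a labelled ligand from melanin-concentrating hormone receptor 1 (Homo sapiens); a higher number here means a weaker inhibitor, a lower number a stronger inhibitor. Compound 1 `CC(C)(C)c1cc(N)c2cc(NC(=O)/C=C/c3ccc(C(F)(F)F)cc3)ccc2n1` gives 0.3 nM. Compound 2 `CCCc1cc(N)c2cc(NC(=O)/C=C/c3ccc(C(C)(C)C)cc3)ccc2n1` gives 22 nM, the higher of the two numbers, so compound 2 is the weaker inhibitor of the pair; the two compounds differ in more than one place, so no single change can be credited with the gap between them. Compound 3 `CCCc1cc(N)c2cc(NC(=O)/C=C/c3ccc(CC)cc3)ccc2n1` has not yet been measured. It differs from compound 2 in one place only: ethyl in place of tert-butyl on an aromatic carbon. Going by the values given here, no measured pair shows what this change alone does, and compound 1 carries a different group at that place together with another change elsewhere. A modest step is expected, most likely towards a somewhat higher number, though it could stay within the scatter. Compound 3 is therefore estimated at 35 nM, with a range from 10 nM to 150 nM. The step this estimate implies is expected to be a 1.6-fold higher number from compound 2 to compound 3 (0.20 log units; within the scatter).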

Compound 3, half-maximal inhibitory concentration: 1.4 nM
Estimate against measurement, compound 3: 25-fold (1.40 log units) above, outside the stated range (below it).
By their numbers in this assay, from the lowest: compound 1; then compound 3; then compound 2.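

In this assay, putting ethyl in place of tert-butyl on an aromatic carbon, para to a large group, gives a 16-fold lower number from compound 2 to compound 3 (1.20 log units; beyond the scatter), a large step well beyond the scatter. Going by these compounds alone, this is the first pair that differs in one place only, and it shows that the group at this position strongly affects the number: the smaller group, with 2 heavy atoms against 4, gives the stronger inhibitor, and neither group has a ring or any hydrogen-bond donors or acceptors. Nothing shown here explains why the step is so large.

From the compounds shown here alone, it remains open whether a methyl group, a longer chain such as propyl, or an amine at this position would give a lower or a higher number. Compound 1 carries trifluoromethyl here but also differs elsewhere, so its effect at this position cannot be separated out.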